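This account rests on a few compounds, and the source may have more. Where it says the series, first, only, none or still open, it means among the compounds named here.

In a functional assay on HT-1080 cells (Homo sapiens) for antiproliferative activity, read by MTT assay, with a stated time of 72 h (a higher number here means a weaker inhibitor, a lower number a stronger inhibitor), compound 1 `COc1ccc(-c2sc(C(=O)O)cc2-c2cc(OC)c(OC)c(OC)c2)cc1` gives 6770 nM while compound 2 `COc1ccc(-c2sccc2-c2cc(OC)c(OC)c(OC)c2)cc1[N+](=O)[O-]` gives 2100 nM and compound 3 `CCOC(=O)c1cc(-c2ccc(OC)c([N+](=O)[O-])c2)c(-c2cc(OC)c(OC)c(OC)c2)s1` gives 26100 nM as the highest of the three numbers. Compound 3 thus stands at the weak end of this small set, and its gaps to compound 1 and to compound 2 both lie beyond the scatter. No two of these compounds differ in one place only, so the series offers no direct measure of any single change.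

The next compound to be read is compound 4 `CCOC(=O)c1cc(-c2ccc(OC)c(O)c2)c(-c2cc(OC)c(OC)c(OC)c2)s1`. It keeps the ethyl ester of compound 3 and carries hydroxy in place of nitro on an aromatic carbon ortho to a methoxy group and meta to a large group. The same difference reads 4-methoxy-3-nitrophenyl to 3-hydroxy-4-methoxyphenyl.

Without a matched step, the expectation is tentative. A moderate move to a lower number, beyond the scatter, is expected because compound 3 gives 26100 nM at the top of the three values, which leaves most of the measured range below it. The estimated step is a 6.5-fold lower number from compound 3 to compound 4 (0.81 log units; beyond the scatter) and its size remains uncertain. Compound 4 is estimated at 4000 nM with an expected range from 500 nM to 20000 nM for now.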

Compound 4, half-maximal inhibitory concentration: 82600 nM
Compound 4: middle estimate off by 21-fold (1.31 log units), on the low side; the whole stated range lies below it.
By their numbers in this assay, from the lowest: compound 2; then compound 1; then compound 3; then compound 4.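

For the compounds shown here, compound 3 and compound 4 form the first matched pair: the ethyl ester and the rest of the core stay fixed while 4-methoxy-3-nitrophenyl becomes 3-hydroxy-4-methoxyphenyl, and this assay gives a 3.2-fold higher number from compound 3 to compound 4 (0.50 log units; beyond the scatter) for this one change. The number therefore responds to the group on this aromatic carbon, ortho to a methoxy group and meta to a large group, and in this ester setting hydroxy gives the higher number of the two, so exchanging nitro for hydroxy here brings no gain. Nothing at hand speaks to the cause of this step.

A single pair cannot show whether the step carries over to a core with a carboxylic acid in place of the ethyl ester, or to a core without either group, as in compound 2. It also leaves open how an amine, a fluorine or a longer alkoxy chain on the same aromatic carbon would read, and whether hydroxy or nitro is the group driving the step.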